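A Methyl on the Ring Nitrogen and an Unmeasured Compound

This account rests on a few compounds, and the source may have more. Where it says the series, first, only, none or still open, it means among the compounds named here.

So far, three compounds have been measured: compound 1 `COc1ccc(C(=O)/C=C/c2cc(Br)c(Br)n2C)c(OC)c1`, compound 2 `COc1ccc(C(=O)/C=C/c2cc(Br)c(Br)[nH]2)c(OC)c1` and compound 3 `O=c1cc(-c2cc(Br)c(Br)[nH]2)oc2ccccc12`. All three were tested in a functional assay on Caco-2 cells (Homo sapiens) for cytotoxicity, read by MTT assay, with stated times of 6 h and 48 h; a lower number here means a stronger inhibitor, a higher number a weaker inhibitor. In this assay compound 1 gives >= 100000 nM, which is a limit of the assay rather than a number. Compound 2 likewise gives only the limit >= 100000 nM in this assay. Compound 3 also gives only the limit >= 100000 nM in this assay.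

Compound 2 and compound 1 differ in one place: methyl in place of hydrogen on an aromatic nitrogen. The step that the two limits leave unreadable from compound 2 to compound 1 cannot be sized because of the limit of >= 100000 nM in this assay, at which 3 of the 3 values shown sit. Compound 3 carries a different core from compound 2, and the difference between the two cores is not broken down here.

Compound 4 `Cn1c(-c2cc(=O)c3ccccc3o2)cc(Br)c1Br` has not yet been measured. It differs from compound 3 by methyl in place of hydrogen on an aromatic nitrogen. Going by the values given here, this is the same change as the one from compound 2 to compound 1, in the same place, so the earlier step is the closest guide.

The step expected is a number no higher from compound 3 to compound 4 (the limit leaves the size open), an estimate only. It rests on compound 3 giving only the limit >= 100000 nM in this assay. It also rests on the unreadable step that the two limits leave unreadable from compound 2 to compound 1, which gives no sign that the methyl moved the value off the limit. Compound 4 is therefore expected to give 100000 nM in this assay, most likely again as a limit.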

Compound 4, half-maximal inhibitory concentration: >= 100000 nM
Compound 4: a limit, no number; the forecaster's own chance of this, stated with the estimate: 85%; the middle value lies on the limit itself.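

No size can be read for the step between compound 3 and compound 4, because each of the two gives only a limit, not a number, in this assay: the limit of >= 100000 nM in this assay, at which 4 of the 4 values shown sit.

The compounds shown leave open whether methyl in place of hydrogen on an aromatic nitrogen changes the read-out at all, and how compounds 1 to 4 would rank against one another in this assay.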